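The compounds below may be only part of what the source reports. "The series", "measured", "known", "first", "only" and "open" are said of these compounds alone.

Of the compounds shown here, three sharing one core have been measured in a functional assay on HL-60 cells (Homo sapiens) for cytotoxicity, read by WST assay, with a stated time of 48 h; on this read-out lower numbers stand for stronger inhibition and higher numbers for weaker inhibition. Compound 1 `Oc1ccccc1/C=C/C[C@H]1C[C@@H]([C@@H](O)c2ccccc2)CO[C@@H]1c1ccccc1` gives 10800 nM. Compound 2 `COc1ccccc1/C=C/C[C@H]1C[C@@H]([C@@H](O)c2ccccc2)CO[C@@H]1c1ccccc1` gives 10100 nM, and compound 3 `Oc1cccc(/C=C/C[C@H]2C[C@@H]([C@@H](O)c3ccccc3)CO[C@@H]2c2ccccc2)c1` gives 12800 nM. Among these three numbers compound 1 holds the second highest, with compound 2 nearest and compound 3 furthest, yet every gap lies within the scatter, so no ordering among them can be claimed.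

Compound 4 `O[C@@H](c1ccccc1)[C@H]1CO[C@H](c2ccccc2)[C@@H](C/C=C/c2ccncc2)C1` has not yet been measured. It differs from compound 1 in one place: pyridin-4-yl in place of 2-hydroxyphenyl on a double-bonded chain carbon bound to a double-bonded chain carbon. Going by the values given here, two measured steps bear on this kind of change, since each also alters the ring on the double-bonded chain carbon. Methyl in place of hydrogen on the oxygen gave a 1.1-fold lower number from compound 1 to compound 2 (0.03 log units; within the scatter), and 3-hydroxyphenyl in place of 2-hydroxyphenyl gave a 1.2-fold higher number from compound 1 to compound 3 (0.07 log units; within the scatter). Neither moved the number beyond the scatter. Among the compounds with values here, no measured step tests a ring carrying a nitrogen or the loss of the hydrogen-bond donor, so the direction of any effect is unknown.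

The number for compound 4 in this assay is therefore expected to stay close to that of compound 1, the estimated step being a 1.1-fold higher number from compound 1 to compound 4 (0.03 log units; within the scatter). Compound 4 is estimated at 11500 nM, within a range from 4500 nM to 30000 nM.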

Compound 4, half-maximal inhibitory concentration: > 100000 nM
Compound 4 gave a limit, no number (the forecaster's own chance of this, stated with the estimate: 15%); middle value at least 8.6-fold (0.93 log units) away from the limit.
By their numbers in this assay, from the lowest: compounds 2, 1 and 3 (each within the scatter of the next). At a limit, above all of these: compound 4.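

In this assay compound 4 gives > 100000 nM, which is a limit of the assay and not a number. Even read as a limit, pyridin-4-yl on this double-bonded chain carbon stands clearly apart from all three earlier rings, with an at least 9.2-fold higher number from compound 1 to compound 4 (0.96 log units; beyond the scatter), an at least 7.8-fold higher number from compound 3 to compound 4 (0.89 log units; beyond the scatter) and an at least 9.9-fold higher number from compound 2 to compound 4 (0.99 log units; beyond the scatter). Going by these compounds alone, the earlier compounds made this position look indifferent to change, since neither moving the hydroxyl group nor capping it with a methyl left the scatter, as in a 1.1-fold lower number from compound 1 to compound 2 (0.03 log units; within the scatter), so compound 4 is the first sign that the ring at this place matters to the read-out.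

The compounds shown do not separate the arrival of the ring nitrogen from the loss of the ring oxygen, and a plain phenyl ring or a phenyl ring carrying an amine at this place would speak to that. They also leave open whether pyridin-3-yl or pyridin-2-yl, with the nitrogen placed elsewhere in the ring, would behave like pyridin-4-yl or like the hydroxyphenyl rings.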